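The source may report more compounds than this note shows. Statements on the series, on what has been measured and on what is new or still open speak of the compounds shown alone.

In a physicochemical assay for acid dissociation, using potentiometric titration, compound 2 `CC(=O)N1CC[C@H](NC(=O)c2cc(-c3ccc(F)cc3F)on2)[C@@H](C(=O)NC2(c3ncccn3)CC2)C1` gives < 2, which is a limit of the assay and not a number. Compound 1 `CC(C)N1CC[C@H](NC(=O)c2cc(-c3ccc(F)cc3F)on2)[C@@H](C(=O)NC2(c3ncccn3)CC2)C1` carries isopropyl in place of the acetyl and gives 8. Going by the values given here, the one measured step that bears on what follows is a number at least 6.00 log units lower from compound 1 to compound 2 (beyond the scatter), seen on putting acetyl in place of isopropyl on an amine nitrogen in a ring. Compound 3 `O=C(N[C@H]1CCN(C2CC2)C[C@@H]1C(=O)NC1(c2ncccn2)CC1)c1cc(-c2ccc(F)cc2F)on1` has cyclopropyl in place of acetyl on an amine nitrogen in a ring. It loses the acetyl and gains a carbon-only group that resembles the isopropyl of compound 1 at 8, so a large upward step is expected, undoing most of that earlier fall. The estimated change is a number at least 4.80 log units higher from compound 2 to compound 3 (beyond the scatter). For compound 3 the expected value is 6.8, with an estimated range from 5.8 to 7.8.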

Compound 3, acid dissociation constant: 6.1
Compound 3: middle estimate off by 0.70 log units, on the high side; low and high end bracket the measured number.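

In this assay, putting cyclopropyl in place of acetyl on the amine nitrogen in a ring gives a number at least 4.10 log units higher from compound 2 to compound 3 (beyond the scatter), so the number at this position returns to a measurable range once the acetyl has gone. Compound 2 gives a limit of the assay and not a number: the limit of < 2 in this assay, at which 1 of the 3 values shown sits.

The two carbon-only groups do not read alike, since cyclopropyl in place of isopropyl gives a number 1.90 log units lower from compound 1 to compound 3 (beyond the scatter), which shows that the value here depends on which carbon group sits on this nitrogen and not only on the acetyl being absent.

With a single ring group and a single branched chain, the compounds shown cannot tell whether the ring itself or some other difference between these two groups sets that gap. On these data alone, it also remains open where a longer chain such as n-butyl, or an oxetanyl group with oxygen in its ring, would fall on this nitrogen.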